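A few compounds are considered here, and "the series" means these few. Any claim that something is new, unique, unknown or untested is made for them only; others in the source may bear on it.

Measured so far in a functional assay on the whole organism with Rattus norvegicus as the target; on this read-out lower numbers stand for an effect already at smaller amounts and higher numbers for an effect only at larger amounts of compound:
- compound 1 `CCN(CCNC(=O)c1cc(Cl)c(N)cc1OC)Cc1ccccc1` gives 0.31 mg/kg
- compound 2 `COc1cc(N)c(Cl)cc1C(=O)NCCN(Cc1ccc(Cl)cc1)C(C)C` gives 3 mg/kg
- compound 3 `COc1cc(NCc2ccccc2)c(Cl)cc1C(=O)NC1CCN(Cc2ccccc2)C1` gives > 30 mg/kg as a limit

The next entry starts from compound 3, which has no number on this read-out. Its > 30 mg/kg in this assay is a limit of the assay. Compound 4 `COc1cc(N(C)C(=O)C(F)(F)F)c(Cl)cc1C(=O)NC1CCN(Cc2ccccc2)C1` has methyl((trifluoromethyl)carbonyl)amino in place of benzylamino on an aromatic carbon, ortho to a chloro group and meta to a methoxy group methyl((trifluoromethyl)carbonyl)amino in place of benzylamino on an aromatic carbon and keeps the rest of compound 3 unchanged.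

Among the compounds with values here, no pair of measured compounds differs in one place only, so the series gives no direct measure of this change. The expectation therefore rests on the two compounds that have numbers and lack benzylamino, compound 1 with 0.31 mg/kg and compound 2 with 3 mg/kg in the same assay. Both also differ from compound 3 elsewhere, which keeps this reasoning weak. An expected at least 10-fold lower number from compound 3 to compound 4 (1.00 log units; beyond the scatter) in this assay points toward an effect at smaller amounts, with its size uncertain since the starting point is only a limit. The estimated value for compound 4 is 3 mg/kg with an expected range from 0.4 mg/kg to 30 mg/kg on this read-out.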

Compound 4, dose for half-maximal effect: 0.3 mg/kg
Beside the measured number, compound 4's estimate is 10-fold (1.00 log units) above it; measured number below the stated range.
By their numbers in this assay, from the lowest: compounds 4 and 1 (each within the scatter of the next); then compound 2. At a limit, above all of these: compound 3.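

In this assay, within the data shown here, methyl((trifluoromethyl)carbonyl)amino in place of benzylamino on an aromatic carbon, ortho to a chloro group and meta to a methoxy group, gives an at least 100-fold lower number from compound 3 to compound 4 (2.00 log units; beyond the scatter), the first reading of a change at this position. With the rest of the structure unchanged, compound 4 gives 0.3 mg/kg while carrying a group with no ring and no hydrogen-bond donor at this position, so neither the six-membered aromatic ring of benzylamino nor its hydrogen-bond donor is needed here for an effect at this dose. Compound 3 carries a limit and not a number, so the step bounds the size of the change without fixing it: the limit of > 30 mg/kg in this assay, at which 1 of the 4 values shown sits.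

The step exchanges the whole group at once, so the contributions of the methyl, the carbonyl and the trifluoromethyl parts of the entering group stay unseparated, and the loss of the benzyl part cannot be told apart from them. Open as well is how a simpler acetylamino or methylamino group would read at this aromatic carbon with the rest of compound 3 kept, and how compounds 1 and 2 relate to this change, as both differ from it elsewhere.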